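The source may report more compounds than this note shows. Statements on the series, on what has been measured and on what is new or still open speak of the compounds shown alone.

Of the compounds shown here, three built on one shared core have been tested in a functional assay on MCF7 cells (Homo sapiens) for inhibition, read by sulforhodamine B assay, with a stated time of 24 h; a lower number here means a stronger inhibitor, a higher number a weaker inhibitor. Compound 1 `O=c1[nH]cnc2c1c(-c1ccccc1)cn2-c1ccc(S(=O)(=O)Nc2nccs2)cc1` gives 6210 nM, compound 2 `O=c1[nH]cnc2c1c(-c1ccccc1)cn2-c1ccc(S(=O)(=O)Nc2ccccn2)cc1` gives 5320 nM, and compound 3 `Cc1nc2c(c(-c3ccccc3)cn2-c2ccc(S(=O)(=O)Nc3nccs3)cc2)c(=O)[nH]1` gives 5800 nM. Compound 3 thus stands second highest of the three numbers, within the scatter of both others. Compound 4 `Cc1nc2c(c(-c3ccccc3)cn2-c2ccc(S(=O)(=O)Nc3ccccn3)cc2)c(=O)[nH]1` differs from compound 3 by pyridin-2-yl in place of 1,3-thiazol-2-yl on a sulfonamide nitrogen. The same exchange has already been seen once, as a 1.2-fold lower number from compound 1 to compound 2 (0.07 log units; within the scatter), and the methyl step a 1.1-fold lower number from compound 1 to compound 3 (0.03 log units; within the scatter) likewise stayed within the scatter. Nothing in these figures points to a step beyond the scatter in this assay for compound 4. Compound 4 is therefore expected at 5000 nM, with a range of 2500 nM to 10000 nM. The estimated 1.2-fold lower number from compound 3 to compound 4 (0.06 log units; within the scatter) is accordingly small.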

Compound 4, half-maximal inhibitory concentration: 5100 nM
Compound 4: the middle estimate sits 1.0-fold (0.01 log units) below what was measured; low and high end bracket the measured number.
By their numbers in this assay, from the lowest: compounds 4, 2, 3 and 1 (each within the scatter of the next).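

In this assay, the exchange of 1,3-thiazol-2-yl for pyridin-2-yl on a sulfonamide nitrogen now has a second reading, a 1.1-fold lower number from compound 3 to compound 4 (0.06 log units; within the scatter), and it agrees with the first: the same change on two cores in this assay, a 1.2-fold lower number (0.07 log units; within the scatter) from compound 1 to compound 2 and a 1.1-fold lower number (0.06 log units; within the scatter) from compound 3 to compound 4, 1.0-fold (0.01 log units) apart, within the scatter of two such steps

Methyl in place of hydrogen on an aromatic carbon also has a second reading, a 1.0-fold lower number from compound 2 to compound 4 (0.02 log units; within the scatter), and it agrees in the same way: the same change on two cores in this assay, a 1.1-fold lower number (0.03 log units; within the scatter) from compound 1 to compound 3 and a 1.0-fold lower number (0.02 log units; within the scatter) from compound 2 to compound 4, 1.0-fold (0.01 log units) apart, within the scatter of two such steps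

Neither change moves the number beyond the scatter on either core. The compounds shown leave open whether a carboxylic acid on the sulfonamide nitrogen, or an amine or a longer chain in place of the methyl, would produce a step beyond the scatter.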